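The source may hold more compounds than are shown below. What is called first, only, known or untested is meant among the compounds shown, and "the series" means these compounds.

Compound 1 `COc1cc(OC)c(C(=O)/C=C/c2ccc(Cl)cc2)c(OC)c1`: 8200 nM
Compound 2 `COc1cc(OC)c(C(=O)/C=C/c2ccc(F)cc2)c(OC)c1`: 10700 nM

Going by the values given here, in a functional assay on MDA-MB-231 cells (Homo sapiens) for cytotoxicity, with a stated time of 48 h (a lower number here means a stronger inhibitor, a higher number a weaker inhibitor), compound 2 gives 10700 nM, which cannot be told apart from compound 1: the only measured step is a 1.3-fold higher number from compound 1 to compound 2 (0.12 log units; within the scatter). Compound 3 `COc1cc(OC)c(C(=O)/C=C/c2ccc([N+](=O)[O-])cc2)c(OC)c1` has nitro in place of fluoro on an aromatic carbon, para to a large group: nitro in place of fluoro on an aromatic carbon. Among the compounds with values here, that measured step swapped fluoro for chloro at the same place, so it offers only limited guidance, since no nitro compound has been measured. With no evidence for a shift in either direction, the expected change is a 1.1-fold lower number from compound 2 to compound 3 (0.05 log units; within the scatter), with no clear step beyond the scatter. For compound 3 the estimated value is 9500 nM, with an expected range from 3500 nM to 26000 nM.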

Compound 3, half-maximal inhibitory concentration: 3300 nM
Compound 3: the middle estimate sits 2.9-fold (0.46 log units) above what was measured; measured number below the stated range.
By their numbers in this assay, from the lowest: compound 3; then compounds 1 and 2 (each within the scatter of the next).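

Nitro in place of fluoro gives a 3.2-fold lower number from compound 2 to compound 3 (0.51 log units; beyond the scatter) in this assay and nitro in place of chloro gives a 2.5-fold lower number from compound 1 to compound 3 (0.40 log units; beyond the scatter) as well. The position para to a large group therefore does respond to its substituent: fluoro and chloro could not be told apart, but nitro stands clearly apart from both. No measurement shown here explains this shift.

The compounds shown leave open whether the lower number is particular to nitro or would also appear with a nitrile or an amine at this place. Going by these compounds, whether nitro would act the same way elsewhere on this ring also remains unknown.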